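Isopropoxy to ethoxy on the benzylamide series

The compounds below may be only part of what the source reports. "The series", "measured", "known", "first", "only" and "open" are said of these compounds alone.

Among the measured compounds shown here, compound 1 `CC(C)Oc1ccc(CNC(=O)c2ccc(C(C)(C)C)cc2)cc1` is the weaker of the two measured members. In an assay on HeLa cells with Bile acid receptor (Homo sapiens) as the target, read by a luciferase reporter, with a stated time of 24 h (a lower number here means that less compound is needed, a higher number that more compound is needed for the effect), compound 1 gives 170 nM, the higher of the two numbers on hand. Compound 2 `CC(C)(C)c1ccc(C(=O)NCc2ccc(C(=O)O)c(Cl)c2)cc1` differs from compound 1 in several places. In this assay compound 2 gives 8.8 nM, and the gap between the two values lies beyond the scatter. For the measured compounds named here, no single-point step between measured compounds is available, so the pair of compound 1 and compound 2 says only that a carboxylic acid bearing partner on the benzylic ring goes with the lower number.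

Compound 3 `CCOc1ccc(CNC(=O)c2ccc(C(C)(C)C)cc2)cc1` is the next point to be measured. It differs from compound 1 by hydrogen in place of methyl on a saturated chain carbon bound to an oxygen on an aromatic ring and a saturated chain carbon. The change is a single carbon on the alkoxy chain and leaves the shared core and the amide untouched. With no measured step of this kind in the series, the expected step in this assay from compound 1 is small and without a clear direction, most likely inside the scatter, with a slight lean toward a higher number. The expected step is a 1.2-fold higher number from compound 1 to compound 3 (0.09 log units; within the scatter). Compound 3 is therefore estimated at 210 nM in this assay, with a range from 90 nM to 480 nM.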

Compound 3, half-maximal effective concentration: 160 nM
For compound 3 the middle estimate is 1.3-fold (0.12 log units) above the measured one; low and high end bracket the measured number.
By their numbers in this assay, from the lowest: compound 2; then compounds 3 and 1 (each within the scatter of the next).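

In this assay, among the compounds shown here, isopropoxy to ethoxy is the first single-place step that can be read, and it gives a 1.1-fold lower number from compound 1 to compound 3 (0.03 log units; within the scatter), which lies within the scatter. At this place on the chain, isopropyl and ethyl are therefore not told apart by this read-out, and removing this methyl brings no change that can be read in either direction. No supporting evidence bears on why the two groups read alike.

As far as these compounds go, a single step within the scatter defines only a narrow stretch of this chain, and whether the same flat reading holds for methoxy or for a longer chain such as butoxy remains open. Equally open, from the compounds shown here alone, is whether a terminal amine or hydroxyl on the chain would give a step beyond the scatter, and so whether this place can move the number in this assay at all.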